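The source may hold more compounds than are shown below. What is called first, only, known or untested is meant among the compounds shown, and "the series" means these compounds.

Measured compounds:
- compound 1, `O=C(NCc1cn(Cc2ccc(F)cc2)nn1)c1cn(-c2ccccc2)nc1-c1ccccc1`, in a functional assay on MCF7 cells (Homo sapiens) for antiproliferative activity, read by sulforhodamine B assay, with a stated time of 48 h (a higher number here means a weaker inhibitor of growth, a lower number a stronger inhibitor of growth), gives 7000 nM
- compound 2, `O=C(NCc1cn(Cc2ccc(C(F)(F)F)cc2)nn1)c1cn(-c2ccccc2)nc1-c1ccccc1`, in this assay gives 840 nM
- compound 3, `O=C(NCc1cn(Cc2ccc(F)cc2)nn1)c1cn(-c2ccccc2)nc1-c1ccc(F)cc1`, in this assay gives 55300 nM

Compound 3 stands highest of the three numbers in this assay: its nearest neighbour is compound 1, reached by the step of a 7.9-fold higher number from compound 1 to compound 3 (0.90 log units; beyond the scatter), and compound 2 lies furthest from it. The unmeasured compound 4, `O=C(NCc1cn(Cc2ccc(C(F)(F)F)cc2)nn1)c1cn(-c2ccccc2)nc1-c1ccc(F)cc1`, differs from compound 3 by trifluoromethyl in place of fluoro on an aromatic carbon. Among the compounds with values here, the one measured step that bears on this change is an 8.3-fold lower number from compound 1 to compound 2 (0.92 log units; beyond the scatter), the same exchange made on the shared core carrying the unsubstituted phenyl rather than the fluorophenyl. Within the data shown here, nothing among the measured compounds shows whether the fluoro on the other ring alters the size of that step. The step from compound 3 to compound 4 in this assay is therefore expected to be of similar size and direction, a 7.9-fold lower number from compound 3 to compound 4 (0.90 log units; beyond the scatter). Among the measured compounds shown here, on that basis compound 4 is estimated at 7000 nM, within a range of 2000 nM to 25000 nM, because the step of an 8.3-fold lower number from compound 1 to compound 2 (0.92 log units; beyond the scatter) is the only guide available.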

Compound 4, concentration for 50% growth inhibition: 810 nM
Beside the measured number, compound 4's estimate is 8.6-fold (0.94 log units) above it, and the stated range ends above it.
By their numbers in this assay, from the lowest: compounds 4 and 2 (each within the scatter of the next); then compound 1; then compound 3.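

In this assay, the change from 4-fluorobenzyl to 4-(trifluoromethyl)benzyl turns out not to be a fixed increment: with a fluoro on the other phenyl it gives a 68-fold lower number from compound 3 to compound 4 (1.83 log units; beyond the scatter), and the step depends on the core that carries it: the same change on two cores in this assay, an 8.3-fold lower number (0.92 log units; beyond the scatter) from compound 1 to compound 2 and a 68-fold lower number (1.83 log units; beyond the scatter) from compound 3 to compound 4, 8.2-fold (0.91 log units) apart, beyond the scatter of two such steps

The fluoro on that other phenyl depends on its partner in the same way, for with 4-(trifluoromethyl)benzyl present it gives a 1.0-fold lower number from compound 2 to compound 4 (0.02 log units; within the scatter), unlike its clear effect with 4-fluorobenzyl: the same change on two cores in this assay, a 7.9-fold higher number (0.90 log units; beyond the scatter) from compound 1 to compound 3 and a 1.0-fold lower number (0.02 log units; within the scatter) from compound 2 to compound 4, 8.2-fold (0.91 log units) apart, beyond the scatter of two such steps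

The two changes therefore do not add up across these four compounds, and with trifluoromethyl in place the fluoro leaves no readable mark on the number.

The compounds shown leave open whether a chlorine, a methoxy group or a nitrile at the place of the trifluoromethyl would show the same dependence on the other ring. They also leave open whether a chlorine or a methyl group on that other phenyl would behave as the fluoro does.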